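The compounds below may be only part of what the source reports. "The series", "measured", "known", "first", "only" and "open" are said of these compounds alone.

Of the compounds shown here, three built on one shared core have been tested in an ADME assay on cells (Hepatocyte, Homo sapiens) for cytotoxicity, read by MTT assay, with a stated time of 90 min, tested at 100 uM; on this read-out lower numbers stand for a stronger effect and higher numbers for a weaker effect at the one concentration tested. Compound 1 `Cc1c(C)c2c(c(C)c1O)CCC(C)(COc1ccc(/C=C3\SC(=O)N(C)C3=O)cc1)O2` gives 147%, compound 2 `Cc1c(C)c2c(c(C)c1CCCCCCN)CCC(C)(COc1ccc(/C=C3\SC(=O)N(C)C3=O)cc1)O2` gives 82.6%, and compound 3 `Cc1c(C)c2c(c(C)c1OC(=O)OC(C)(C)C)CCC(C)(CN1C(=O)S/C(=C\c3ccc(O)cc3)C1=O)O2` gives 65.1%, the lowest of the three numbers and beyond the scatter from both others. Within the data shown here, the only step measured so far, a number 64.4 percentage points lower from compound 1 to compound 2 (beyond the scatter), concerns a different change and does not bear directly on what follows. Compound 4 `Cc1c(C)c2c(c(C)c1O)CCC(C)(CN1C(=O)S/C(=C\c3ccc(O)cc3)C1=O)O2` differs from compound 3 by hydrogen in place of tert-butoxycarbonyl on an oxygen on an aromatic ring. Compound 4 thus carries the same free hydroxy as compound 1, whose value stands far above that of compound 3, although those two differ in a second place as well. A rise is therefore expected, a number 34.9 percentage points higher from compound 3 to compound 4 (beyond the scatter). Compound 4 is estimated at 100%, between 70% and 140%.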

Compound 4, a percentage reported as activity, at one concentration (the size of the read-out at that concentration, not a potency): 110%
Compound 4: middle estimate off by 10 percentage points, on the low side; measured number inside the range.
By their numbers in this assay, from the lowest: compound 3; then compound 2; then compound 4; then compound 1.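

Removing the tert-butoxycarbonyl from the oxygen on the aromatic ring gives a number 44.9 percentage points higher from compound 3 to compound 4 (beyond the scatter) in this assay. So the read-out at this place responds to a group attached through the oxygen, whereas the earlier step showed only a hydroxy replaced by 6-aminohexyl. In both pairs the compound with the free hydroxy has the higher number, although the two pairs differ elsewhere in the molecule.

Going by these compounds, how a methyl ether or an acetyl ester on this oxygen would read remains open. No measurement shown here explains the size of this step.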